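Replacing Isopropyl on Nitrogen: What to Expect of Compound 4

The compounds below may be only part of what the source reports. "The series", "measured", "known", "first", "only" and "open" are said of these compounds alone.

Measured in a functional assay on a cell-free system (plasma, Oryctolagus cuniculus) for inhibition, with stated times of 5 min, 1 min and 6 min; on this read-out lower numbers stand for stronger inhibition and higher numbers for weaker inhibition:
- compound 1 `CCOC(=O)c1c(C)nc(-c2ccc(C#N)cc2)n1OC`: 13400 nM
- compound 2 `CCOC(=O)c1c(C)nc(-c2ccccc2)n1OC`: > 30000 nM (a limit of the assay)
- compound 3 `CCOC(=O)c1c(C)nc(-c2cccc(C#N)c2)n1C(C)C`: 9260 nM

In this assay compound 3 stands at 9260 nM, within the usual scatter of compound 1 at 13400 nM. The next step leads to compound 4 `CCOC(=O)c1c(C)nc(-c2cccc(C#N)c2)n1OCc1ccncc1`, with (pyridin-4-yl)methoxy in place of isopropyl on an aromatic nitrogen.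

Going by the values given here, the only measured step, an at least 2.2-fold higher number from compound 1 to compound 2 (0.35 log units; beyond the scatter), is at least modest and beyond the scatter, but it replaces cyano with hydrogen on an aromatic carbon and so does not test this change. Among the compounds with values here, no measured step isolates the group on that nitrogen. Compound 1 and compound 3 carry different groups there, yet they also differ in a second place, so their closeness gives only weak guidance. No step beyond the scatter is therefore expected, although the uncertainty is wide. The expected change is a 1.3-fold lower number from compound 3 to compound 4 (0.12 log units; within the scatter). A result at the limit of > 30000 nM in this assay, at which 1 of the 3 values shown sits, remains possible for compound 4. For compound 4 the estimated value is 7000 nM, with an expected range of 1500 nM to 30000 nM.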

Compound 4, half-maximal inhibitory concentration: 6200 nM
For compound 4 the middle estimate is 1.1-fold (0.05 log units) above the measured one, and the stated range covers the measured number.
By their numbers in this assay, from the lowest: compounds 4, 3 and 1 (each within the scatter of the next, the first and the last beyond it). At a limit, above all of these: compound 2.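

In this assay the group on this aromatic nitrogen is now seen on its own, with the rest of the molecule held constant, which the pair of compound 1 and compound 3 could not offer. The exchange gives a 1.5-fold lower number from compound 3 to compound 4 (0.17 log units; within the scatter) and so does not separate isopropyl from (pyridin-4-yl)methoxy, even though the entering group brings a six-membered aromatic ring and two hydrogen-bond acceptors. This position therefore accepts a much larger group without a readable shift in the number, and nothing shown here gives a reason for that.

As far as these compounds go, whether the ring nitrogen of the pyridine matters stays open, since a benzyloxy group on the same nitrogen would be needed to tell. So does the outcome with an amine or a carboxylic acid at the end of a chain there.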